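Methoxy in place of amino on two cores

The compounds below may be only part of what the source reports. "The series", "measured", "known", "first", "only" and "open" are said of these compounds alone.

Of the compounds shown here, three have been measured in an ADME assay on HEK293 cells (Homo sapiens) for inhibition, read by MTT assay, with a stated time of 2 days; a lower number here means a stronger inhibitor, a higher number a weaker inhibitor. In this assay compound 1 `Nc1cccc(/C=C/c2ccccc2O)c1` gives 96 ug/mL. Compound 2 `COc1cccc(/C=C/c2ccccc2O)c1` gives 20 ug/mL, so that the change methoxy in place of amino on an aromatic carbon gave a 4.8-fold lower number from compound 1 to compound 2 (0.68 log units; beyond the scatter). Compound 3 `Nc1cccc(/C=C/c2ccc(O)cc2)c1` gives 7 ug/mL, the lowest number of the three, with its steps to both other compounds beyond the scatter. Among the measured compounds shown here, compound 3 and compound 1 have the same atoms joined differently; the difference between the two cores is not broken down here, and the two values show only that compound 3 sits well below compound 1.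

Compound 4 `COc1cccc(/C=C/c2ccc(O)cc2)c1` has not been measured. It differs from compound 3 by methoxy in place of amino on an aromatic carbon; the place given for this change matches word for word the place given for the change from compound 1 to compound 2, so it is the same change, made on the core of compound 3 rather than on the core of compound 1. This change occurs twice among the compounds shown, once measured and once open.

For the measured compounds named here, for compound 4 the step is expected to be a 3.5-fold lower number from compound 3 to compound 4 (0.54 log units; beyond the scatter), somewhat smaller than the one measured instance, since a single step on another core is a thin basis. That expectation rests on one instance, a 4.8-fold lower number from compound 1 to compound 2 (0.68 log units; beyond the scatter), and on compound 3 giving 7 ug/mL. Compound 4 is therefore expected at 2 ug/mL, with a range from 0.7 ug/mL to 6 ug/mL.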

Compound 4, half-maximal inhibitory concentration: 24 ug/mL
Beside the measured number, compound 4's estimate is 12-fold (1.08 log units) below it, and the stated range ends below it.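

Made on the second core, methoxy in place of amino on an aromatic carbon gave a 3.4-fold higher number from compound 3 to compound 4 (0.54 log units; beyond the scatter), so the step runs the opposite way to the one on the first core. In this assay the change therefore carries over from one core to the other in neither size nor direction, and the two steps differ by more than repeated measurements would explain: the same change on two cores in this assay, a 4.8-fold lower number (0.68 log units; beyond the scatter) from compound 1 to compound 2 and a 3.4-fold higher number (0.54 log units; beyond the scatter) from compound 3 to compound 4, 16-fold (1.22 log units) apart, beyond the scatter of two such steps. This shows that, within these four compounds, the outcome of the change depends on the core it is made on, but it rests on a single pair per core and gives no reason for the reversal, nor any rule for predicting the direction on a further core.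

The compounds shown leave open how other groups at the same place would behave on each of the two cores, for instance an ethoxy, a dimethylamino or a carboxylic acid, and whether any of them would give steps that agree across the cores. They also leave open whether the reversal belongs to amino and methoxy alone or extends to such groups, which a matched pair on both cores would be needed to tell.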